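The compounds below may be only part of what the source reports. "The series", "measured", "known", "first", "only" and "open" are said of these compounds alone.

Compound 1 `C=C(Br)C(=O)Nc1ccc(C(=O)/C=C/c2cccc(OC)c2OC)cc1`: 380 nM
Compound 2 `COc1cccc(/C=C/C(=O)c2ccc(N)cc2)c1`: 19000 nM
Compound 3 `COc1ccccc1/C=C/C(=O)c1ccc(N)cc1`: 7800 nM

In a functional assay on HeLa cells (Homo sapiens) for antiproliferative activity, with a stated time of 48 h (on this read-out higher numbers stand for weaker inhibition and lower numbers for stronger inhibition), compound 3 holds the middle place among these three numbers, with compound 2 reading higher and compound 1 reading lower, both beyond the scatter. Compound 4 `COc1cccc(/C=C/C(=O)c2ccc(N)cc2)c1OC` is compound 3 with methoxy in place of hydrogen on an aromatic carbon, ortho to a methoxy group methoxy in place of hydrogen on an aromatic carbon and so carries the methoxy groups of both compound 2 and compound 3. Among the compounds with values here, no measured pair shows this change alone, so only a modest expectation is possible. The expected 1.3-fold higher number from compound 3 to compound 4 (0.11 log units; within the scatter) stays within the scatter of this assay and leans slightly towards weaker inhibition. For compound 4 the estimate is 10000 nM with an expected range from 4000 nM to 25000 nM in this assay.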

Compound 4, half-maximal inhibitory concentration: 6800 nM
Beside the measured number, compound 4's estimate is 1.5-fold (0.17 log units) above it, and the stated range covers the measured number.
By their numbers in this assay, from the lowest: compound 1; then compounds 4 and 3 (each within the scatter of the next); then compound 2.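

In this assay, methoxy in place of hydrogen, ortho to a methoxy group, gives a 1.1-fold lower number from compound 3 to compound 4 (0.06 log units; within the scatter) and so does not separate these two compounds, while the same kind of change gives a 2.8-fold lower number from compound 2 to compound 4 (0.45 log units; beyond the scatter) and does go beyond the scatter. Far more separates the compounds at the nitrogen, where hydrogen in place of (1-bromoethenyl)carbonyl gives an 18-fold higher number from compound 1 to compound 4 (1.25 log units; beyond the scatter) on this read-out. No measurement shown here explains these steps. On these data alone, whether a hydroxyl or a fluorine at this ring position would read differently stays open, as does whether a plain acetyl on the nitrogen, without bromine, would match compound 1.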